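A Phenyl Swap Repeated on a Second Core

This account rests on a few compounds, and the source may have more. Where it says the series, first, only, none or still open, it means among the compounds named here.

Compound 1 `Cc1cc(=O)n(-c2cccc(F)c2)nc1C(=O)Nc1ccc(Oc2ncnc3[nH]ccc23)c(F)c1` and compound 2 `Cc1ccc(-n2nc(C(=O)Nc3ccc(Oc4ncnc5[nH]ccc45)c(F)c3)c(C)cc2=O)cc1` share one core and differ in a single place. In a functional assay on HepG2 cells (Homo sapiens) for cytotoxicity, read by MTT assay, with a stated time of 72 h (a lower number here means a stronger inhibitor, a higher number a weaker inhibitor), compound 1 gives 23100 nM. In this assay compound 2 gives 18800 nM. The change between them is 4-methylphenyl in place of 3-fluorophenyl on an aromatic nitrogen, and it made a step of a 1.2-fold lower number from compound 1 to compound 2 (0.09 log units; within the scatter), so the two values show no order between them.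

Compound 3 `Cc1cc(=O)n(-c2cccc(F)c2)nc1C(=O)Nc1ccc(Oc2ncnc3c2ccn3C)cc1` is built on a different core; the difference between the core of compound 1 and the core of compound 3 is not broken down here. For compound 3 this assay reports only a limit, > 60000 nM. Compound 3 thus stands at the limit of > 60000 nM in this assay, at which 1 of the 3 values shown sits.

Compound 4 `Cc1ccc(-n2nc(C(=O)Nc3ccc(Oc4ncnc5c4ccn5C)cc3)c(C)cc2=O)cc1` has not yet been measured in this assay. Among the compounds with values here, it differs from compound 3 by 4-methylphenyl in place of 3-fluorophenyl on an aromatic nitrogen, which is the same change as the one from compound 1 to compound 2, made at the same place. The step from compound 3 to compound 4 is expected to be a step that the limit leaves unreadable from compound 3 to compound 4. This expectation rests on the earlier step of a 1.2-fold lower number from compound 1 to compound 2 (0.09 log units; within the scatter), which the same change made on the core of compound 1 and which stayed within the scatter. Compound 4 is therefore estimated at 70000 nM, with a range from 30000 nM to 160000 nM, and a limit rather than a number is the likelier report, since compound 3 itself gave only a limit.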

Compound 4, half-maximal inhibitory concentration: 33800 nM
Estimate against measurement, compound 4: 2.1-fold (0.32 log units) above; measured number inside the range.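

In this assay, carrying 4-methylphenyl in place of 3-fluorophenyl over to the second core gave a step of an at least 1.7-fold lower number from compound 3 to compound 4 (0.24 log units; that floor lies within the scatter). In this assay compound 3 gives only a limit, > 60000 nM, so this step has a floor and no fixed size. The result therefore neither shows the change behaving alike on the two cores nor shows it behaving differently, and the comparison stands as follows: the same change on two cores in this assay, a 1.2-fold lower number (0.09 log units; within the scatter) from compound 1 to compound 2 and an at least 1.7-fold lower number (0.24 log units; that floor lies within the scatter) from compound 3 to compound 4; the limit leaves it open whether they differ

The compounds shown carry only 3-fluorophenyl and 4-methylphenyl at this place on the aromatic nitrogen, so it remains open how a phenyl ring bearing an amine or a carboxylic acid, or one with a longer chain in place of the methyl group, would read in this assay. The core of compound 1 and the core of compound 3 also differ from each other, and the compounds shown do not break that difference into single changes, so what each part of it contributes to the values remains open as well.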